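The compounds below may be only part of what the source reports. "The series", "measured", "known", "first", "only" and "open" are said of these compounds alone.

This account concerns compound 2 `COc1ccccc1-c1ncnn1-c1cc(OC)c(OC)c(OC)c1` and the not yet tested compound 4 `COc1cc(-n2ncnc2-c2cccc(F)c2)cc(OC)c1OC`, judged in a functional assay on A549 cells (Homo sapiens) for antiproliferative activity, read by MTT assay, with a stated time of 72 h; a higher number here means a weaker inhibitor, a lower number a stronger inhibitor. For compound 2 only a limit was obtained: in this assay compound 2 gives > 10000 nM. Its companions fare the same. Compound 1 `COc1cc(-n2ncnc2-c2ccc(OC(C)C)cc2)cc(OC)c1OC` reaches only a limit, > 10000 nM, in this assay. Compound 3 `COc1ccc(-n2ncnc2-c2cc(OC)c(OC)c(OC)c2)cc1` likewise stops at the limit of > 10000 nM in this assay. Compound 2 therefore stands at the limit of > 10000 nM in this assay, at which 3 of the 3 values shown sit, together with the other two. The change leading to compound 4 is 3-fluorophenyl in place of 2-methoxyphenyl on an aromatic carbon. For the measured compounds named here, with every measured compound at the limit, no step between measured compounds can be sized. The writer expects the step that the limit leaves unreadable from compound 2 to compound 4 to stay within the scatter, with a limit the likeliest outcome again. Compound 4 is expected near 15000 nM, between 3000 nM and 60000 nM.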

Compound 4, half-maximal inhibitory concentration: > 10000 nM
Compound 4: no number, only a limit; the forecaster's own chance of this, stated with the estimate: 70%; the middle value does not contradict the limit.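

Like compound 2, compound 4 reaches only a limit, so no step between compound 2 and compound 4 can be read: the limit of > 10000 nM in this assay, at which 4 of the 4 values shown sit. The compounds shown leave open whether any change on the shared core affects antiproliferative activity.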